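Swapping the chain amine on a weak A549 inhibitor

This account rests on a few compounds, and the source may have more. Where it says the series, first, only, none or still open, it means among the compounds named here.

Compound 3 `COc1ccc(-n2nc(C(=O)Nc3ccc(Oc4ccnc5cc(OCCCN6CCCC6)c(OC)cc45)c(F)c3)c(C)cc2=O)cc1` gives the highest of the three numbers in a functional assay on A549 cells (Homo sapiens) for inhibition, read by MTT assay, with a stated time of 72 h (a lower number here means a stronger inhibitor, a higher number a weaker inhibitor), with a reading of 2770 nM. Compound 1 `COc1cc2c(Oc3ccc(NC(=O)c4nn(-c5ccccc5OC(F)(F)F)c(=O)cc4C)cc3F)ccnc2cc1OCCCN1CCN(C)CC1` gives 130 nM in this assay, and compound 2 `COc1cc2c(Oc3ccc(NC(=O)c4nn(-c5cccc(F)c5)c(=O)cc4C)cc3F)ccnc2cc1OCCCN1CCN(C)CC1` gives 150 nM. Among the compounds with values here, the one measured single-point step, a 1.2-fold higher number from compound 1 to compound 2 (0.06 log units; within the scatter), shows an aromatic swap that leaves the number essentially unchanged. Compound 4 `COc1ccc(-n2nc(C(=O)Nc3ccc(Oc4ccnc5cc(OCCCN6CCN(C)CC6)c(OC)cc45)c(F)c3)c(C)cc2=O)cc1` differs from compound 3 by 4-methylpiperazin-1-yl in place of pyrrolidin-1-yl on a saturated chain carbon, three bonds along the chain from an oxygen on an aromatic ring. Within the data shown here, no measured step isolates this change, since compounds 1 and 2 differ from compound 3 in more than one place, so any expectation is loosely held. A modest improvement is expected, a 3.1-fold lower number from compound 3 to compound 4 (0.49 log units; beyond the scatter), giving compound 4 an estimated value of 900 nM in this assay, within a range of 250 nM to 3200 nM.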

Compound 4, half-maximal inhibitory concentration: 2200 nM
Beside the measured number, compound 4's estimate is 2.4-fold (0.39 log units) below it, within the range that was stated.
By their numbers in this assay, from the lowest: compounds 1 and 2 (each within the scatter of the next); then compounds 4 and 3 (each within the scatter of the next).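

In this assay, replacing pyrrolidin-1-yl with 4-methylpiperazin-1-yl on the chain gives a 1.3-fold lower number from compound 3 to compound 4 (0.10 log units; within the scatter), so with 4-methoxyphenyl on the aromatic nitrogen, this amine swap has no clear effect. The group on the aromatic nitrogen matters far more, with a 15-fold higher number from compound 2 to compound 4 (1.17 log units; beyond the scatter) and a 17-fold higher number from compound 1 to compound 4 (1.23 log units; beyond the scatter). No evidence here explains these large steps. From the compounds shown here alone, it remains open whether pyrrolidin-1-yl would also match 4-methylpiperazin-1-yl with 3-fluorophenyl or 2-(trifluoromethoxy)phenyl on that nitrogen. Going by these compounds, how a morpholine on the same chain would compare also remains open.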